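The source may report more compounds than this note shows. Statements on the series, on what has been measured and on what is new or still open speak of the compounds shown alone.

Measured so far in a functional assay on A549 cells (Homo sapiens) for inhibition, read by sulforhodamine B assay, tested at 10 uM; on this read-out lower numbers stand for less inhibition of growth and higher numbers for more inhibition of growth at the one concentration tested:
- compound 1 `COc1cc(C2CC(c3ccccc3)=NN2C(C)=O)ccc1OCc1cn(Cc2ccc([N+](=O)[O-])cc2)nn1` — 0%
- compound 2 `COc1cc(C2CC(c3cc(OC)c(OC)c(OC)c3)=NN2C(C)=O)ccc1OCc1cn(Cc2ccc([N+](=O)[O-])cc2)nn1` — 68%
- compound 3 `COc1ccc(C2=NN(C(C)=O)C(c3ccc(OCc4cn(Cc5ccc([N+](=O)[O-])cc5)nn4)c(OC)c3)C2)cc1` — 43%

Compound 3 stands second of the three: compound 2 lies above it by a number 25 percentage points lower from compound 2 to compound 3 (beyond the scatter) (going the other way), and compound 1 lies below it by a number 43 percentage points higher from compound 1 to compound 3 (beyond the scatter).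

Compound 4 is `COc1cc(C2CC(c3cccc4ccccc34)=NN2C(C)=O)ccc1OCc1cn(Cc2ccc([N+](=O)[O-])cc2)nn1`. The change from compound 3 is naphthalen-1-yl in place of 4-methoxyphenyl on a carbon with a double bond to nitrogen.

The two steps that bear on this both alter the same aryl group on the carbon double-bonded to nitrogen. Going from compound 1 to compound 2 gave a number 68 percentage points higher from compound 1 to compound 2 (beyond the scatter); going from compound 2 to compound 3 gave a number 25 percentage points lower from compound 2 to compound 3 (beyond the scatter). Across these, the aryl carrying no hydrogen-bond acceptor (compound 1) sits lowest, one acceptor (compound 3) in the middle, three acceptors (compound 2) highest. Naphthalen-1-yl brings no acceptor and no methoxy at all, so no measured step is a direct parallel; the closest comparison is compound 1 with its plain phenyl.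

Compound 4 is therefore expected to fall below compound 3, the estimated step being a number 23 percentage points lower from compound 3 to compound 4 (beyond the scatter). The estimate for compound 4 in this assay is 20%, with a range of 0% to 50%.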

Compound 4, percent growth inhibition at one concentration: 89%
Compound 4: the middle estimate sits 69 percentage points below what was measured; measured number outside the range, above it.
By their numbers in this assay, from the lowest: compound 1; then compound 3; then compound 2; then compound 4.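

Working notes on the aryl group on the carbon with a double bond to nitrogen, in this assay: naphthalen-1-yl gives the highest number of the four compounds, above both the 4-methoxyphenyl (a number 46 percentage points higher from compound 3 to compound 4 (beyond the scatter)) and the 3,4,5-trimethoxyphenyl (a number 21 percentage points higher from compound 2 to compound 4 (beyond the scatter)), so this position tolerates a larger fused aryl with two six-membered aromatic rings of carbon only. Compound 4 goes against the order seen in compound 1, compound 3 and compound 2, where the number rose with the hydrogen-bond acceptors on this aryl, and the comparison with plain phenyl (a number 89 percentage points higher from compound 1 to compound 4 (beyond the scatter)) shows that two aryl groups with no such acceptor can lie at opposite ends of the series, so acceptor count alone does not order these compounds. No measurement at hand accounts for the rise.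

The compounds shown leave open whether the gain depends on the second ring itself or on how it is joined, a question that naphthalen-2-yl or a biphenyl-4-yl group at this position would address. They also leave open how a 4-dimethylaminophenyl or 4-carboxyphenyl group would compare, and whether the order holds in a full concentration series or in other cell lines.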